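Dropping the Fluorinated Ring from an Amine Nitrogen

The source may hold more compounds than are shown below. What is called first, only, known or untested is meant among the compounds shown, and "the series" means these compounds.

Of the compounds shown here, two have been measured in a functional assay on HeLa cells (Homo sapiens) for cytotoxicity, read by MTT assay, with a stated time of 48 h; a higher number here means a weaker inhibitor, a lower number a stronger inhibitor. Compound 1 `COc1ccc(N/C(CCNC2=CC(=O)c3ccccc3C2=O)=N\S(=O)(=O)c2ccc(C)cc2)c(OC)c1` gives 67600 nM. Compound 2 `Cc1ccc(S(=O)(=O)/N=C(/CCNC2=CC(=O)c3ccccc3C2=O)Nc2cc(F)c(F)c(F)c2)cc1` gives 8580 nM, and of the two numbers it is the lower one: the step of a 7.9-fold lower number from compound 1 to compound 2 (0.90 log units; beyond the scatter) came from putting a 3,4,5-trifluorophenyl in place of a 2,4-dimethoxyphenyl on an amine nitrogen, so compound 2 is the stronger inhibitor of the pair by a margin beyond the scatter.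

Compound 3 `Cc1ccc(S(=O)(=O)/N=C(\N)CCNC2=CC(=O)c3ccccc3C2=O)cc1` has not been measured. It differs from compound 2 in one place: hydrogen in place of 3,4,5-trifluorophenyl on an amine nitrogen. The nitrogen that carried an aromatic ring in both measured compounds now carries only hydrogen. A single measured step touches this position, a 7.9-fold lower number from compound 1 to compound 2 (0.90 log units; beyond the scatter), and it shows that exchanging one ring for another already shifts the number by a modest amount. Among the compounds with values here, removing the ring altogether is a larger change than any measured pair shows, and no measured compound has a bare amino there, so the direction rests on that one step. Compound 3 is therefore expected to be a weaker inhibitor, with an estimated step of a 4.7-fold higher number from compound 2 to compound 3 (0.67 log units; beyond the scatter). The estimated value for compound 3 is 40000 nM, within a range of 10000 nM to 160000 nM.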

Compound 3, half-maximal inhibitory concentration: 24600 nM
Compound 3: middle estimate off by 1.6-fold (0.21 log units), on the high side; measured number inside the range.
By their numbers in this assay, from the lowest: compound 2; then compound 3; then compound 1.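

With compound 3 the nitrogen can be read without any ring on it, and in this assay the bare amino lands between the two compounds that carry a ring. Taking away the 3,4,5-trifluorophenyl gives a 2.9-fold higher number from compound 2 to compound 3 (0.46 log units; beyond the scatter), a loss of strength, whereas taking away the 2,4-dimethoxyphenyl gives a 2.7-fold lower number from compound 1 to compound 3 (0.44 log units; beyond the scatter), a gain, so a ring on this nitrogen is not good or bad in itself: compared with plain hydrogen, one ring gives a stronger inhibitor and the other a weaker one. Nothing measured here explains why the two rings pull in opposite directions.

Still open, as far as these compounds go, is where an unsubstituted phenyl ring would fall on this nitrogen, a result that would help separate the contribution of the ring itself from that of the fluorines or methoxy groups on it. A methyl or a benzyl in the same place would also show whether a group without a ring directly on the nitrogen behaves more like hydrogen or more like either ring.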